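This account rests on a few compounds, and the source may have more. Where it says the series, first, only, none or still open, it means among the compounds named here.

Measured so far:
Compound 1 `c1ccc(-c2cn3ccnc3c(-c3ccc4ncn(C5CCCCC5)c4c3)n2)cc1`: in a functional assay on LOX IMVI cells (Homo sapiens) for inhibition, read by sulforhodamine B assay, with a stated time of 48 h, tested at 10 uM (on this read-out higher numbers stand for more inhibition at the one concentration tested (going by the name of the read-out) and lower numbers for less inhibition), compound 1 gives 39.6%.
Compound 2 `COc1ccccc1-c1cn2ccnc2c(-c2ccc3ncn(C4CCCCC4)c3c2)n1`: in this assay compound 2 gives 5.13%.

Going by the values given here, compound 2 stands lowest of the two numbers in this assay; its only neighbour is compound 1, and the step of a number 34.5 percentage points lower from compound 1 to compound 2 (beyond the scatter) lies beyond the scatter. Among the compounds with values here, that is the single measured step, methoxy in place of hydrogen on an aromatic carbon, and it concerns the same aromatic carbon that changes next.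

Compound 3 `Fc1ccccc1-c1cn2ccnc2c(-c2ccc3ncn(C4CCCCC4)c3c2)n1` differs from compound 2 by fluoro in place of methoxy on an aromatic carbon. Compound 3 thus carries at that carbon neither the hydrogen of compound 1 nor the methoxy of compound 2, so the two measured values bracket the plausible outcome. Given the large downward step a number 34.5 percentage points lower from compound 1 to compound 2 (beyond the scatter) when methoxy entered, taking the methoxy out again is expected to recover part of that loss, an upward step in this assay, though two points cannot say whether fluoro sits nearer hydrogen or nearer methoxy, so the range is kept wide.

For compound 3 an inhibition of 20% is expected, within 3% to 40%. This expectation amounts to a step of a number 14.9 percentage points higher from compound 2 to compound 3 (beyond the scatter).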

Compound 3, a percentage reported as inhibition, at one concentration (the size of the read-out at that concentration, not a potency): 5.77%
The estimate for compound 3 lay 14.2 percentage points above the measured number; the range from low to high includes it.
By their numbers in this assay, from the lowest: compounds 2 and 3 (each within the scatter of the next); then compound 1.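

In this assay, the fluoro group gives a number 0.6 percentage points higher from compound 2 to compound 3 (within the scatter), and against the unsubstituted phenyl it gives a number 33.8 percentage points lower from compound 1 to compound 3 (beyond the scatter). The loss seen with the 2-methoxyphenyl group is therefore not confined to methoxy: at this aromatic carbon, ortho to a large group, both substituents shown go with low inhibition, and only the hydrogen of compound 1 goes with the higher number. Fluoro brings one heavy atom and no hydrogen-bond acceptor, whereas methoxy brings two heavy atoms and one acceptor, so neither the second heavy atom nor the acceptor is required for the loss in these compounds. No measurement at hand explains why either substituent lowers the number.

As far as these compounds go, with only two substituents beyond hydrogen, it remains open whether every group on this carbon costs inhibition, or whether an amine or a carboxylic acid there would keep the level of compound 1. Also open, from the compounds shown here alone, is whether fluoro or methoxy on another carbon of the same ring would give a similar loss, and how these single-concentration numbers relate to potency.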